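Swapping the aryl group on the ring nitrogen

The source may hold more compounds than are shown below. What is called first, only, known or untested is meant among the compounds shown, and "the series" means these compounds.

Three compounds share a core and differ only in the group attached to an amide-type nitrogen in a ring. Compound 1 `COc1ccc(OC)c(N2C(=O)CSC2c2cccc(C(=O)NCCCCc3ccccc3)c2)c1` carries a 2,5-dimethoxyphenyl there and gives 48% in a functional assay on SJSA-1 cells (Homo sapiens) for inhibition, read by CCK-8 assay, with a stated time of 72 h, tested at 1 uM; a lower number here means less inhibition, a higher number more inhibition at the concentration tested (going by the name of the read-out). Compound 2 `CCN1C(=O)CSC1c1cccc(C(=O)NCCCCc2ccccc2)c1` carries an ethyl and gives 3%. Compound 3 `COc1cc(F)ccc1N1C(=O)CSC1c1cccc(C(=O)NCCCCc2ccccc2)c1` carries a 4-fluoro-2-methoxyphenyl and gives 77%, the highest of the three numbers, standing a number 29 percentage points higher from compound 1 to compound 3 (beyond the scatter) and a number 74 percentage points higher from compound 2 to compound 3 (beyond the scatter).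

Compound 4 `O=C(NCCCCc1ccccc1)c1cccc(C2SCC(=O)N2c2ccccc2F)c1` is the untested one; the change is 2-fluorophenyl in place of 4-fluoro-2-methoxyphenyl on an amide-type nitrogen in a ring. The measured steps that bear on it are the aryl swap a number 29 percentage points higher from compound 1 to compound 3 (beyond the scatter), which was modest, and the aryl-to-alkyl swaps a number 45 percentage points lower from compound 1 to compound 2 (beyond the scatter) and a number 74 percentage points higher from compound 2 to compound 3 (beyond the scatter), which were large. Compound 4 keeps an aryl group, so a large loss as with compound 2 is not expected, but the modest step between the two aryl variants suggests that the exact aryl does matter. A modest downward step a number 22 percentage points lower from compound 3 to compound 4 (beyond the scatter) is therefore expected. Compound 4 is estimated at 55%, in the range 25% to 80%.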

Compound 4, a percentage reported as inhibition, at one concentration (the size of the read-out at that concentration, not a potency): 80%
Compound 4: the middle estimate sits 25 percentage points below what was measured; measured number inside the range.
By their numbers in this assay, from the lowest: compound 2; then compound 1; then compounds 3 and 4 (each within the scatter of the next).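

Placing 2-fluorophenyl on the ring nitrogen in this assay gives a number 3 percentage points higher from compound 3 to compound 4 (within the scatter) and so shows that an aryl group here can do without a methoxy group, which compounds 1 and 3 both carry. The aryl-for-alkyl gain seen with compound 3 appears again with a second aryl group, as a number 77 percentage points higher from compound 2 to compound 4 (beyond the scatter) shows, yet having an aryl group is not enough on its own: compound 1 goes against any such rule, with a number 32 percentage points higher from compound 1 to compound 4 (beyond the scatter) separating two aryl variants. Nothing measured here explains why these aryl groups differ.

As far as these compounds go, what the fluorine contributes remains open, and a plain phenyl or a 2-chlorophenyl would test this. From the compounds shown here alone, it is also open whether a ring other than phenyl, such as a pyridine or a cyclohexyl, would keep the same level of inhibition.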